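A few compounds are considered here, and "the series" means these few. Any claim that something is new, unique, unknown or untested is made for them only; others in the source may bear on it.

Compound 2 `CCc1c(Cc2c(F)cccc2Cl)nc(SCC(=O)c2ccc(F)cc2)[nH]c1=O` is measured in an ADME assay on MT4 cells (Homo sapiens) for cytotoxicity, read by MTT assay; a higher number here means that more compound is tolerated, a lower number that less compound is tolerated. There compound 2 gives only an assay limit, > 57000 nM. Its close relative compound 1 `Cc1c(Cc2c(F)cccc2Cl)nc(SCC(=O)c2ccc(F)cc2)[nH]c1=O` also gives only a limit, > 59000 nM, in this assay. The step that the two limits leave unreadable from compound 1 to compound 2 is therefore not readable in size. Compound 3 `CCc1c(Cc2c(F)cccc2F)nc(SCC(=O)c2ccc(F)cc2)[nH]c1=O` differs from compound 2 by fluoro in place of chloro on an aromatic carbon. For the measured compounds named here, no measured step covers this change, and the two limits allow no comparison of sizes. The step that the limit leaves unreadable from compound 2 to compound 3 is thus estimated as no change beyond the scatter. Compound 3 is expected to give 60000 nM in this assay, within 30000 nM to 120000 nM, most likely again only as a limit.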

Compound 3, half-maximal cytotoxic concentration: > 60000 nM
Compound 3: a limit, no number; the forecaster's own chance of this, stated with the estimate: 80%; the middle value sits exactly at the limit.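

Compound 2 and compound 3 each give only a limit in this assay, and the step between them cannot be read. The compounds shown leave open the concentration at which compound 1, compound 2 or compound 3 harms these cells, and whether fluoro in place of chloro changes it.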